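Swapping a Sulfanyl Link for a Sulfonyl Link

A few compounds are considered here, and "the series" means these few. Any claim that something is new, unique, unknown or untested is made for them only; others in the source may bear on it.

Compound 1 `O=C(/C(=C\c1ccc(Br)cc1)Sc1ccc(Br)cc1)c1ccc(Cl)cc1`: 1000 nM
Compound 2 `Cc1ccc(C)c(/C=C(/Sc2ccc(Br)cc2)C(=O)c2ccc(Cl)cc2)c1`: 10000 nM
Compound 3 `O=C(/C(=C\c1c(O)cc(O)cc1O)Sc1ccc(Br)cc1)c1ccc(Cl)cc1`: 50000 nM

All three were tested in a functional assay on DU-145 cells (Homo sapiens) for inhibition, read by trypan blue exclusion, with a stated time of 96 h; on this read-out lower numbers stand for stronger inhibition of growth and higher numbers for weaker inhibition of growth. Compound 3 gives the highest number of the three; compound 2 stands nearest (a 5.0-fold higher number from compound 2 to compound 3 (0.70 log units; beyond the scatter)) and compound 1 furthest (a 50-fold higher number from compound 1 to compound 3 (1.70 log units; beyond the scatter)). Compound 4 `O=C(/C(=C\c1c(O)cc(O)cc1O)S(=O)(=O)c1ccc(Br)cc1)c1ccc(Cl)cc1` has not yet been measured. It differs from compound 3 in one place: (4-bromophenyl)sulfonyl in place of (4-bromophenyl)sulfanyl on a double-bonded chain carbon bound to a carbonyl carbon and a double-bonded chain carbon. Within the data shown here, every measured step here (a 10-fold higher number from compound 1 to compound 2 (1.00 log units; beyond the scatter) among them) swaps the aryl group on a double-bonded chain carbon bound to a double-bonded chain carbon; none touches the (4-bromophenyl)sulfanyl group, so no measured step bears on this change. Without such a guide, a step within the scatter is expected: no change at the digits printed from compound 3 to compound 4 (within the scatter). Compound 4 is therefore estimated at 50000 nM, in a range from 12000 nM to 200000 nM.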

Compound 4, concentration for 50% growth inhibition: > 100000 nM
Compound 4 was reported as a limit; the forecaster's own chance of this, stated with the estimate: 15%; middle value at least 2.0-fold (0.30 log units) from the limit.
By their numbers in this assay, from the lowest: compound 1; then compound 2; then compound 3. At a limit, above all of these: compound 4.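

Among these compounds, this is the first change to the (4-bromophenyl)sulfanyl group itself, and it gives an at least 2.0-fold higher number from compound 3 to compound 4 (0.30 log units; that floor lies within the scatter). Adding the two sulfonyl oxygens therefore brings no gain in growth inhibition on the 2,4,6-trihydroxyphenyl compound, although the floor of this step does not by itself establish a loss. Compound 4 is reported only as a limit in this assay: the limit of > 100000 nM in this assay, at which 1 of the 4 values shown sits.

Going by these compounds, whether the same swap behaves alike with the aryl groups of compound 1 and compound 2 remains open. So does the outcome of a sulfinyl link or an amine-bearing aryl group at this place.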